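The source may report more compounds than this note shows. Statements on the series, on what has been measured and on what is new or still open speak of the compounds shown alone.

Measured so far in an ADME assay on MT4 cells (Homo sapiens) for cytotoxicity, read by MTT assay; on this read-out lower numbers stand for higher toxicity in this test and higher numbers for lower toxicity in this test:

- compound 1 `Cc1cc(C)cc(S(=O)(=O)c2c(C(=O)NC(C)C(=O)NCCn3c(C)cnc3[N+](=O)[O-])[nH]c3ccc(Cl)cc23)c1`: 16000 nM
- compound 2 `Cc1cc(C)cc(S(=O)(=O)c2c(C(=O)NCc3cccc(F)c3F)[nH]c3ccc(Cl)cc23)c1`: > 51100 nM

Compound 1 gives an actual number. Compound 2 gives > 51100 nM, and this is a limit of the assay, not a number. Its true position on the scale is therefore unknown.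

Compound 3 `Cc1cc(C)cc(S(=O)(=O)c2c(C(=O)NCc3cccc(N)c3)[nH]c3ccc(Cl)cc23)c1` has not yet been measured. It keeps the shared core of compound 2 and carries one structural change: 3-aminophenyl in place of 2,3-difluorophenyl on a saturated chain carbon bound to an amide-type nitrogen. Going by the values given here, no measured pair shows this change, so any forecast is uncertain.

Compound 1 shows that the shared core can give a measurable value in this assay, 16000 nM. A modest move towards higher toxicity in this test therefore seems likely, although compound 3 could also end at a limit. The expected change is an at least 1.8-fold lower number from compound 2 to compound 3 (0.26 log units; that floor lies within the scatter). For compound 3 the estimated value is 28000 nM, with an expected range from 9000 nM to 80000 nM.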

Compound 3, half-maximal cytotoxic concentration: > 53400 nM
Compound 3: a limit, no number; the forecaster's own chance of this, stated with the estimate: 40%; middle value at least 1.9-fold (0.28 log units) away from the limit.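

Going by these compounds alone, compound 2 and compound 3 both end at a limit of the assay rather than a number, so no step between them can be read. Left open is where their true values lie, and so whether 3-aminophenyl in place of 2,3-difluorophenyl changes the value at all.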